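Amine variation on the dithiocarbamate butenolide series

This account rests on a few compounds, and the source may have more. Where it says the series, first, only, none or still open, it means among the compounds named here.

Compound 1 `CCN(CC)C(=S)SCC1=CC(=O)OC1` and compound 2 `CN(C)C(=S)SCC1=CC(=O)OC1` share one core and differ only in the amine on the thiocarbonyl carbon. In a functional assay on PC-3 cells (Homo sapiens) for antiproliferative activity, read by MTT assay, with a stated time of 72 h (a higher number here means a weaker inhibitor, a lower number a stronger inhibitor), compound 1 gives only a limit, > 50 ug/mL. In this assay compound 2 likewise gives only a limit, > 50 ug/mL. The step that the two limits leave unreadable from compound 1 to compound 2 is therefore not readable, as the limit of > 50 ug/mL in this assay, at which 2 of the 2 values shown sit, shows. Compound 3 `O=C1C=C(CSC(=S)N2CCCC2)CO1` carries the change (pyrrolidin-1-yl in place of dimethylamino on a thiocarbonyl carbon). For the measured compounds named here, no measured step reads on this change, so no direction in this assay can be set from it. Compound 3 is expected to stand near the same limit, estimated at 60 ug/mL with a range from 30 ug/mL to 150 ug/mL. The implied step that the limit leaves unreadable from compound 2 to compound 3 is expected to stay within the scatter.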

Compound 3, half-maximal inhibitory concentration: > 50 ug/mL
Compound 3 gave a limit, no number (the forecaster's own chance of this, stated with the estimate: 80%); the middle value does not contradict the limit.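

For the compounds shown here, compound 3 joins compound 1 and compound 2 in giving only a limit in this assay, so no step among the three can be read: the limit of > 50 ug/mL in this assay, at which 3 of the 3 values shown sit. The compounds shown leave open how these amines rank on the shared core.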